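Swapping a Phosphate for an Ethyl Group

This account rests on a few compounds, and the source may have more. Where it says the series, first, only, none or still open, it means among the compounds named here.

Measured compounds:
- compound 1, `CCCCCCCCc1ccc(C(=O)Nc2ccccc2[N+](=O)[O-])cc1`, a limit at > 600000 nM
- compound 2, `CCCCCCCCc1ccc(CNc2cccc(OP(=O)(O)O)c2)cc1`, a limit at > 600000 nM
- compound 3, `CCCCCCCCc1ccc(CNc2cc(C)ccc2C(=O)O)cc1`, 21700 nM

These values come from an assay for binding affinity to serine/threonine-protein kinase PLK1 (Homo sapiens), read by fluorescence polarization, with a stated time of 45 min; on this read-out higher numbers stand for weaker inhibition and lower numbers for stronger inhibition. Compound 2 stands at a limit in this assay, not at a number, and it is not alone there: the limit of > 600000 nM in this assay, at which 2 of the 3 values shown sit. For the measured compounds named here, compound 3 is the only compound of the three with a measured number, and it sits far from that limit.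

Compound 4, `CCCCCCCCc1ccc(CNc2cccc(CC)c2)cc1`, has not yet been measured. It differs from compound 2 by a group of 2 heavy atoms (2 carbon; no ring) in place of a group of 5 heavy atoms (4 oxygen, 1 phosphorus; no ring), on an aromatic carbon, the entering ethyl sitting meta to a large group. Going by the values given here, no step between measured compounds exists, so the size of the step in this assay can only be guessed. A limit can only move toward a number or stay a limit, so the step from compound 2 to compound 4 should be downward or none beyond the scatter.

Compound 4 is expected at about 250000 nM, within 40000 nM to 900000 nM. That estimate means an expected step of an at least 2.4-fold lower number from compound 2 to compound 4 (0.38 log units; beyond the scatter).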

Compound 4, half-maximal inhibitory concentration: > 600000 nM
Compound 4 gave a limit, no number; the forecaster's own chance of this, stated with the estimate: 45%; middle value at least 2.4-fold (0.38 log units) away from the limit.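

Compound 2 and compound 4 both give only a limit, not a number, so no step between them can be read in this assay: the limit of > 600000 nM in this assay, at which 3 of the 4 values shown sit.

The compounds shown leave open whether putting ethyl in place of the group on compound 2 changes binding at all.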